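The compounds below may be only part of what the source reports. "The series", "measured", "known", "first", "only" and "open" are said of these compounds alone.

Compound 1 `Cc1cc(C)c(S(=O)(=O)N2CCC(N3CCC(O)CC3)CC2)c(C)c1` in an ADME assay on HCT-116 cells (Homo sapiens) for cytotoxicity, read by CellTiter-Glo, with a stated time of 72 h (a higher number here means a weaker inhibitor, a lower number a stronger inhibitor), gives > 5000 nM, which is a limit of the assay and not a number.
Compound 2 `Cc1cc(C)c(S(=O)(=O)N2CCC(N3CCC(C)OC3)CC2)c(C)c1` gives > 5000 nM, again a limit.
Compound 3 `Cc1cc(C)c(S(=O)(=O)N2CCC(N3CCCCCC3)CC2)c(C)c1` gives > 5000 nM, also a limit.

Compound 1 therefore stands only at the limit of > 5000 nM in this assay, at which 3 of the 3 values shown sit, with no number of its own. Compound 4 `Cc1cc(C)c(S(=O)(=O)N2CCC(N3CCC(Cc4ccc(F)cc4)CC3)CC2)c(C)c1` differs from it by 4-fluorobenzyl in place of hydroxy on a saturated ring carbon. Among the compounds with values here, the steps that touch the same ring, a step that the two limits leave unreadable from compound 1 to compound 2 and a step that the two limits leave unreadable from compound 1 to compound 3, are both unreadable, so no measured step bears a readable size on this change, and nothing beyond the scatter can be expected in either direction. Compound 4 is expected at about 4000 nM, with a range of 1200 nM to 20000 nM; the step of an at least 1.2-fold lower number from compound 1 to compound 4 (0.09 log units; that floor lies within the scatter) is an estimate only, and a limit is as likely as a number.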

Compound 4, half-maximal inhibitory concentration: > 5000 nM
Compound 4 was reported as a limit (the forecaster's own chance of this, stated with the estimate: 55%); middle value at least 1.2-fold (0.09 log units) away from the limit.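

Within the data shown here, compound 4, like compound 1, gives only a limit, so no step between them can be read: the limit of > 5000 nM in this assay, at which 4 of the 4 values shown sit. The compounds shown leave open whether any group at this place gives a measurable value in this assay.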